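Chloro in place of methoxy on compound 1

The compounds below may be only part of what the source reports. "The series", "measured", "known", "first", "only" and "open" are said of these compounds alone.

Among the measured compounds shown here, in a functional assay on MOLT-4 cells (Homo sapiens) for antiproliferative activity, read by cell counting, with a stated time of 2 days (a higher number here means a weaker inhibitor, a lower number a stronger inhibitor), compound 1 `COc1ccc(Nc2nc(N)c(C(=O)c3ccccc3)s2)cc1` gives 230 nM, the highest of the three numbers measured so far. Compound 2 `COc1ccc(Nc2nc(N)c(C(=O)c3ccc(Cl)cc3)s2)cc1` gives 13 nM, and compound 3 `COc1ccc(Nc2nc(N)c(C(=O)c3ccc(OC)c(OC)c3)s2)cc1` gives 37 nM. Compound 4 `Nc1nc(Nc2ccc(Cl)cc2)sc1C(=O)c1ccccc1` has not yet been measured. It differs from compound 1 as follows: chloro in place of methoxy on an aromatic carbon. This is chloro in place of methoxy on an aromatic carbon, para to a large group.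

For the measured compounds named here, only one measured step bears on this change, and it does so indirectly. The large step of an 18-fold lower number from compound 1 to compound 2 (1.25 log units; beyond the scatter) brings in chloro, but in place of hydrogen, and compound 2 keeps its methoxy. Going by the values given here, no measured pair shows what happens when methoxy leaves, so the size of that step cannot simply be carried over. The expected change is therefore modest, with no clear shift beyond the scatter and only a slight lean towards a higher number: a 1.5-fold higher number from compound 1 to compound 4 (0.18 log units; within the scatter) is the estimated step. For compound 4 the expected value is 350 nM, with an estimated range from 70 nM to 1800 nM.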

Compound 4, half-maximal inhibitory concentration: > 10000 nM
Compound 4: no number, only a limit (the forecaster's own chance of this, stated with the estimate: 8%); middle value at least 28-fold (1.45 log units) away from the limit.
By their numbers in this assay, from the lowest: compound 2; then compound 3; then compound 1. At a limit, above all of these: compound 4.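

In this assay compound 4 gives > 10000 nM, which is a limit of the assay and not a number. Among the compounds shown here, putting chloro in place of methoxy on this aromatic carbon, para to a large group, brings an at least 43-fold higher number from compound 1 to compound 4 (1.63 log units; beyond the scatter), so on the core of compound 1 this position, which the earlier compounds left unchanged, is far from indifferent. Chloro does not move the number one way wherever it stands: in another place, replacing hydrogen, it brings an 18-fold lower number from compound 1 to compound 2 (1.25 log units; beyond the scatter), while here the number moves in the opposite direction.

The compounds shown do not separate the departure of methoxy from the arrival of chloro, and a hydroxy or ethoxy group at this position could help to tell the two apart. From the compounds shown here alone, how far the true value of compound 4 lies past its limit also stays open.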